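Acyl variation in a cyanoguanidine series of atrial antagonists

The source may report more compounds than this note shows. Statements on the series, on what has been measured and on what is new or still open speak of the compounds shown alone.

Measured so far:
compound 1 `N#CN/C(=N\CCNC(=O)c1ccc(N=[N+]=[N-])cc1)NCCCOc1cccc(CN2CCCCC2)c1`, in a functional assay on cardiac atrium for antagonist activity at histamine H2 receptor (Cavia porcellus) (a lower number here means a less potent compound, a higher number a more potent compound, by a factor of ten per unit of this negative logarithm), compound 1 gives 7.9
compound 2 `N#CN/C(=N\CCCNC(=O)c1ccc(N=[N+]=[N-])cc1)NCCCOc1cccc(CN2CCCCC2)c1`, in this assay compound 2 gives 6.36
compound 3 `N#CN/C(=N\CCNC(=O)c1ccccc1[N+](=O)[O-])NCCCCOc1cccc(CN2CCCCC2)c1`, in this assay compound 3 gives 7.52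

Compound 1 stands highest of the three numbers. Compound 3 is nearest, below it by a gap beyond the usual scatter; compound 2 is furthest, also below it beyond the scatter.

Compound 4 `N#CN/C(=N\CCNC(=O)CCc1ccccc1)NCCCOc1cccc(CN2CCCCC2)c1` keeps the core of compound 1 and changes only the amide end: phenethyl in place of 4-azidophenyl on a carbonyl carbon. For the measured compounds named here, no measured pair isolates this change, so the expectation rests on compound 1 alone. A modest loss is expected, a number 0.50 log units lower from compound 1 to compound 4 (beyond the scatter), since the change removes an aromatic amide while leaving the rest of the structure untouched. Compound 4 is estimated at 7.4, with a range from 6.7 to 8.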

Compound 4, negative logarithm of the antagonist equilibrium constant: 6.27
Compound 4: middle estimate off by 1.13 log units, on the high side, and the stated range ends above it.
By their numbers in this assay, from the lowest: compounds 4 and 2 (each within the scatter of the next); then compound 3; then compound 1.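

In this assay, for the compounds shown here, the amide end of the core of compound 1 proves sensitive: phenethyl in place of 4-azidophenyl on a carbonyl carbon gives a number 1.63 log units lower from compound 1 to compound 4 (beyond the scatter) as the first single-place step. Keeping one six-membered aromatic ring of carbon only at this end, with a close heavy-atom count, does not hold the number. Nothing available explains the size of this step.

From the compounds shown here alone, whether the loss follows the departure of the azide or the chain in phenethyl stays open. Plain phenyl or benzyl on the same carbonyl carbon would separate the two.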